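One aryl swap on the shared core

This account rests on a few compounds, and the source may have more. Where it says the series, first, only, none or still open, it means among the compounds named here.

Measured so far in a functional assay on A549 cells (Homo sapiens) for inhibition, read by MTT assay, with a stated time of 24 h; on this read-out higher numbers stand for weaker inhibition and lower numbers for stronger inhibition:
compound 1 `CCOC(=O)C1=Cc2ccccc2OC1(OCc1cn(CC(=O)Nc2cccc(Cl)c2)nn1)C(F)(F)F` gives 12800 nM.
compound 2 `CCOC(=O)C1=Cc2ccccc2OC1(OCc1cc(-c2ccc(C)cc2)no1)C(F)(F)F` gives > 150000 nM, which is a limit of the assay rather than a number.
compound 3 `CCOC(=O)C1=Cc2ccccc2OC1(OCc1cc(-c2ccc3ccccc3c2)no1)C(F)(F)F` gives > 150000 nM, again a limit rather than a number.

Within the data shown here, compound 1 is thus the only member of this small set with a readable number. The other two values sit at the limit of > 150000 nM in this assay, at which 2 of the 3 values shown sit. Among the measured compounds shown here, the only change between measured compounds, from compound 2 to compound 3, a step that the two limits leave unreadable from compound 2 to compound 3, concerns a different part of the molecule, and its size cannot be read because both ends are limits.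

Compound 4 `CCOC(=O)C1=Cc2ccccc2OC1(OCc1cn(CC(=O)Nc2ccc(OC)cc2)nn1)C(F)(F)F` has not yet been measured. It differs from compound 1 in 4-methoxyphenyl in place of 3-chlorophenyl on an amide-type nitrogen. For the measured compounds named here, no measured pair covers a change of this kind, so no step gives a direction or a size to expect, and the plainest expectation is a value close to that of compound 1. Compound 4 is therefore estimated at 15000 nM, with a range from 5000 nM to 60000 nM. The step this estimate means, a 1.2-fold higher number from compound 1 to compound 4 (0.07 log units; within the scatter), is expected to stay within the usual scatter.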

Compound 4, half-maximal inhibitory concentration: 29400 nM
The estimate for compound 4 lay 2.0-fold (0.29 log units) below the measured number; low and high end bracket the measured number.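

In this assay, among these compounds, 4-methoxyphenyl in place of 3-chlorophenyl on the amide-type nitrogen gives a 2.3-fold higher number from compound 1 to compound 4 (0.36 log units; beyond the scatter), the first step in this set whose size can be read. A higher number means weaker inhibition here, so this change costs a modest amount of inhibition, yet compound 4 still gives a readable number rather than a limit. The swap removes the chlorine and brings in a methoxy group, and the place of the group on the ring changes with it, so this one step cannot separate those changes, and nothing shown gives a cause for it.

From the compounds shown here alone, a 3-methoxyphenyl or 4-chlorophenyl group, or a plain phenyl, on the same nitrogen would help show whether the identity of the group or its place on the ring goes with the step, and that question stays open. The step from compound 2 to compound 3 cannot be read, as both compounds stand at a limit and not at a number: the limit of > 150000 nM in this assay, at which 2 of the 4 values shown sit.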